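A few compounds are considered here, and "the series" means these few. Any claim that something is new, unique, unknown or untested is made for them only; others in the source may bear on it.

Series notes. The shared core carries a variable group on the aromatic nitrogen. Compound 3 `CCCCC(CC)n1ccc2cc(/C(C)=C/C(=O)Nc3ccccc3OCCCC(=O)O)ccc21` gives 7.1 nM in an assay on Prostate gland for inhibition of steroid 5-alpha-reductase (Rattus norvegicus) (on this read-out lower numbers stand for stronger inhibition and higher numbers for weaker inhibition), the lowest of the three numbers measured. Compound 2 `CCCC(CC)n1ccc2cc(/C(C)=C/C(=O)Nc3ccccc3OCCCC(=O)O)ccc21` gives 9.3 nM, and the step of a 1.3-fold lower number from compound 2 to compound 3 (0.12 log units; within the scatter) stays within the scatter. Compound 1 `CC(C)=CCn1ccc2cc(/C(C)=C/C(=O)Nc3ccccc3OCCCC(=O)O)ccc21` gives 120 nM; the steps of a 13-fold lower number from compound 1 to compound 2 (1.11 log units; beyond the scatter) and a 17-fold lower number from compound 1 to compound 3 (1.23 log units; beyond the scatter) are the only large ones seen. Compound 4 `C/C(=C\C(=O)Nc1ccccc1OCCCC(=O)O)c1ccc2c(ccn2C(C)c2ccccc2)c1` is unmeasured; its change from compound 3 is 1-phenylethyl in place of 1-ethylpentyl on an aromatic nitrogen. Within the data shown here, no measured step places an aromatic ring on this nitrogen, so the two large steps bear only loosely, showing that the group on the nitrogen matters. A step within the scatter or a modest rise in number is expected, a 2.1-fold higher number from compound 3 to compound 4 (0.32 log units; beyond the scatter). For compound 4 the estimate is 15 nM, within 4 nM to 60 nM.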

Compound 4, half-maximal inhibitory concentration: 19 nM
Compound 4: the middle estimate sits 1.3-fold (0.10 log units) below what was measured; the measured number falls inside the stated range.
By their numbers in this assay, from the lowest: compounds 3 and 2 (each within the scatter of the next); then compound 4; then compound 1.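

In this assay, 1-phenylethyl on the aromatic nitrogen gives a 2.7-fold higher number from compound 3 to compound 4 (0.43 log units; beyond the scatter) and a 2.0-fold higher number from compound 2 to compound 4 (0.31 log units; beyond the scatter), so a six-membered aromatic ring of carbon only is accepted here at a modest cost against the two saturated groups. Against 3-methylbut-2-en-1-yl the same group gives a 6.3-fold lower number from compound 1 to compound 4 (0.80 log units; beyond the scatter), so the lower numbers are not confined to saturated chains. Nothing available explains these steps.

Open, going by these compounds, is how a benzyl group, lacking the methyl of 1-phenylethyl, would compare. Also open, on these data alone, is how an amine or a carboxylic acid on the new ring would compare.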